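The source may hold more compounds than are shown below. What is called first, only, known or untested is meant among the compounds shown, and "the series" means these compounds.

In an ADME assay on microsomes from liver (Rattus norvegicus) for metabolic stability (on this read-out lower numbers stand for a shorter-lived compound and higher numbers for a longer-lived compound), compound 2 (`CC(C)C(c1ccc(-c2ccc3cccc(F)c3c2)[nH]c1=O)C1SC(=O)NC1=O`) gives 0.76 h and compound 3 (`CC(C)[C@H](C[C@H]1OC(=O)NC1=O)c1ccc(-c2ccc3cccc(F)c3c2)[nH]c1=O`) gives 0.95 h so the two numbers lie within the scatter of each other. For compound 1 (`CCC(/C=C1\OC(=O)NC1=O)(CC)c1ccc(-c2ccc3cccc(F)c3c2)[nH]c1=O`) this assay reports the value > 3 h which is a limit and not a number. Compound 4 (`CC(C)C(CC1NC(=O)NC1=O)c1ccc(-c2ccc3cccc(F)c3c2)[nH]c1=O`) differs from compound 2 by one change ((2,5-dioxoimidazolidin-4-yl)methyl in place of 2,4-dioxo-1,3-thiazolidin-5-yl on a saturated chain carbon bound to an aromatic carbon and a saturated chain carbon) in which (2,5-dioxoimidazolidin-4-yl)methyl takes the place of 2,4-dioxo-1,3-thiazolidin-5-yl on a saturated chain carbon bound to an aromatic carbon and a saturated chain carbon. Within the data shown here, no measured step covers this change, so with compound 3 at 0.95 h as the nearest guide, only a slight rise within the scatter is expected in this assay here. The expected step (a 1.3-fold higher number from compound 2 to compound 4 (0.12 log units; within the scatter)) is therefore small. Compound 4 is estimated at 1 h with an expected range from 0.5 h to 2.2 h in this measurement.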

Compound 4, half-life: 0.35 h
Estimate against measurement, compound 4: 2.9-fold (0.46 log units) above; the whole stated range lies above it.
By their numbers in this assay, from the lowest: compound 4; then compounds 2 and 3 (each within the scatter of the next). At a limit, above all of these: compound 1.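

In this assay, putting (2,5-dioxoimidazolidin-4-yl)methyl in place of 2,4-dioxo-1,3-thiazolidin-5-yl gives a 2.2-fold lower number from compound 2 to compound 4 (0.34 log units; beyond the scatter), so the read-out at this saturated chain carbon does respond to the group it carries. Among these compounds, this is the first step that can be read here, and it is a modest one. Nothing measured here bears on what in the change lies behind it. Still open, on these data alone, is how a carboxylic acid or an open-chain amide would behave at this place. Also open, as far as these compounds go, is whether the ring or its added chain carbon carries the step.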